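Removing a methoxy from the benzylamine arm of a diaryl ether series

This account rests on a few compounds, and the source may have more. Where it says the series, first, only, none or still open, it means among the compounds named here.

Of the compounds shown here, two have been measured in a functional assay on DLD-1 cells (Homo sapiens) for inhibition, read by MTT assay, with a stated time of 72 h; a lower number here means a stronger inhibitor, a higher number a weaker inhibitor. Compound 1 `COc1cc(Oc2cccc(Nc3ccccc3)c2)cc(OC)c1CNCCNC(C)=O` gives 6010 nM in this assay, while compound 2 `COc1ccc(CNCc2c(OC)cc(Oc3cccc(Nc4ccccc4)c3)cc2OC)cc1` gives 1910 nM. Within the data shown here, compound 2 therefore holds the lowest of the two numbers so far, and the only step known is a 3.1-fold lower number from compound 1 to compound 2 (0.50 log units; beyond the scatter), which reaches it from compound 1.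

Compound 3 `COc1cc(Oc2cccc(Nc3ccccc3)c2)cc(OC)c1CNCc1ccccc1` has not yet been measured. It differs from compound 2 by hydrogen in place of methoxy on an aromatic carbon. Among the measured compounds shown here, no measured step touches this methoxy itself; the one step on record, a 3.1-fold lower number from compound 1 to compound 2 (0.50 log units; beyond the scatter), changed the whole arm on the saturated chain carbon bound to the amine nitrogen and so bears only loosely on it. A step within or near the scatter is therefore expected, with no firm direction, and the estimate for compound 3 in this assay is 2500 nM, between 900 nM and 7000 nM, which would mean a step of a 1.3-fold higher number from compound 2 to compound 3 (0.12 log units; within the scatter).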

Compound 3, half-maximal inhibitory concentration: 5220 nM
Compound 3: middle estimate off by 2.1-fold (0.32 log units), on the low side; the range from low to high includes it.
By their numbers in this assay, from the lowest: compound 2; then compounds 3 and 1 (each within the scatter of the next).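

In this assay, this methoxy on the aromatic carbon para to a large group proves to be more than a minor feature, since taking it away gives a 2.7-fold higher number from compound 2 to compound 3 (0.44 log units; beyond the scatter) and the loss of those 2 heavy atoms alone lies beyond the scatter. The benzyl arm without its methoxy also stands apart from the acetamidomethyl arm by no more than a 1.2-fold lower number from compound 1 to compound 3 (0.06 log units; within the scatter) within this assay, so among these three compounds only the 4-methoxybenzyl arm separates from the others. No measurement at hand explains why the methoxy has this effect.

From the compounds shown here alone, whether a hydroxy group, a chlorine or an ethoxy group on the same aromatic carbon would match the methoxy remains open. So does whether a methoxy elsewhere on this ring would give the same result.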